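Trimethoxyphenyl pyrazole chalcones: amino to dichloro swap

The compounds below may be only part of what the source reports. "The series", "measured", "known", "first", "only" and "open" are said of these compounds alone.

Notes on the series. Compound 1 `COc1cc(-c2cc(/C=C/C(=O)c3ccc(N)cc3)[nH]n2)cc(OC)c1OC` and compound 2 `COc1ccc(-c2cc(/C=C/C(=O)c3ccc(OC)c(OC)c3)[nH]n2)cc1` share the pyrazole-linked enone core and differ in both aryl ends. In a functional assay on HCT-15 cells (Homo sapiens) for cytotoxicity, read by sulforhodamine B assay, with a stated time of 48 h, tested at 1 uM (on this read-out higher numbers stand for a weaker effect at the one concentration tested and lower numbers for a stronger effect), compound 1 gives 60%, and in the same this assay compound 2 gives 65%; these two numbers lie within the scatter of each other, so no order between them can be read. For the measured compounds named here, with only two measured compounds and no single-site step between them, nothing in the numbers so far says how a change on the carbonyl-bound aryl shifts the read-out.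

Compound 3 `COc1cc(-c2cc(/C=C/C(=O)c3ccc(Cl)c(Cl)c3)[nH]n2)cc(OC)c1OC` is the next one to be measured. Relative to compound 1 it carries the change (3,4-dichlorophenyl in place of 4-aminophenyl on a carbonyl carbon). Going by the values given here, no measured pair shows this kind of exchange, so the expectation is for no step beyond the scatter, in either direction. The estimated step from compound 1 to compound 3 in this assay is a number 5 percentage points lower from compound 1 to compound 3 (within the scatter). Compound 3 is therefore expected to give about 55% in this assay, in a range from 35% to 80%.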

Compound 3, a percentage reported as activity, at one concentration (the size of the read-out at that concentration, not a potency): 86%
Estimate against measurement, compound 3: 31 percentage points below; measured number outside the range, above it.
By their numbers in this assay, from the lowest: compounds 1 and 2 (each within the scatter of the next); then compound 3.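

In this assay the series gains its first single-site step: with the rest of compound 1 held fixed, 3,4-dichlorophenyl in place of 4-aminophenyl on a carbonyl carbon gives a number 26 percentage points higher from compound 1 to compound 3 (beyond the scatter) and thus a weaker effect at the one concentration tested. The read-out therefore responds to the aryl group at this place, which compounds 1 and 2 could not show since they differ at both aryl ends. No measurement shown here gives a reason for this step.

Still open, as far as these compounds go, is whether the step follows from losing the amino group or from gaining the two chlorine atoms, a question that a plain phenyl or a 4-chlorophenyl on the same carbon would address. From the compounds shown here alone, whether the step carries over to a different aryl group at the other end of the core also remains unknown.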